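Triazole substituent removal in an adenosine A3 ligand series

This account rests on a few compounds, and the source may have more. Where it says the series, first, only, none or still open, it means among the compounds named here.

Measured so far:
compound 1 `CCNC(=O)[C@H]1O[C@@H](n2cnc3c(NC)nc(-n4cc(Cc5ccccc5)nn4)nc32)[C@H](O)[C@@H]1O` — 2.8 nM
compound 2 `CNc1nc(-c2cn(Cc3cccc(Cl)c3)nn2)nc2c1ncn2[C@@H]1O[C@H](CO)[C@@H](O)[C@H]1O` — 81.1 nM
compound 3 `CNc1nc(-n2cc(CC3CCCC3)nn2)nc2c1ncn2[C@@H]1O[C@H](CO)[C@@H](O)[C@H]1O` — 1.3 nM

In an assay on CHO cells for displacement of a labelled ligand from adenosine receptor A3 (Homo sapiens) (on this read-out higher numbers stand for weaker inhibition and lower numbers for stronger inhibition), compound 1 gives 2.8 nM and stands second highest of the three numbers. Nearest is compound 3, which gives 1.3 nM, a gap beyond the scatter; furthest is compound 2, which gives 81.1 nM.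

Compound 4 `CCNC(=O)[C@H]1O[C@@H](n2cnc3c(NC)nc(-n4ccnn4)nc32)[C@H](O)[C@@H]1O` differs from compound 1 in one place: hydrogen in place of benzyl on an aromatic carbon. Going by the values given here, no pair of measured compounds shows this change; all three carry a group on that carbon, so its removal is untested here. A step toward a higher number, beyond the scatter, is expected. Compound 4 is estimated at 40 nM, with a range from 6 nM to 400 nM. The expected step is a 14-fold higher number from compound 1 to compound 4 (1.15 log units; beyond the scatter).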

Compound 4, inhibition constant: 2.1 nM
Estimate against measurement, compound 4: 19-fold (1.28 log units) above; measured number below the stated range.
By their numbers in this assay, from the lowest: compounds 3, 4 and 1 (each within the scatter of the next, the first and the last beyond it); then compound 2.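

In this assay, hydrogen in place of benzyl on an aromatic carbon of the five-membered ring gives a 1.3-fold lower number from compound 1 to compound 4 (0.12 log units; within the scatter), a step within the scatter. On the core of compound 1, this position therefore holds its number without any group beyond hydrogen, and the benzyl ring adds nothing measurable in this read-out. No available evidence offers an explanation for this result.

Still open, from the compounds shown here alone, is whether an amine, a carboxylic acid or a longer chain on this carbon would leave the number unchanged. Also open, going by these compounds, is whether the same removal on the core of compound 3 gives a similar step.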